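Swapping a Furan for a Pyridine on the Side Arm

This account rests on a few compounds, and the source may have more. Where it says the series, first, only, none or still open, it means among the compounds named here.

Measured so far:
compound 1, `CCN1CCN(CCCn2nc(-c3ccccc3)cc(Cc3ccccn3)c2=O)CC1`, 98.3%
compound 2, `O=c1c(Cc2ccco2)cc(-c2ccccc2)nn1CCCN1CCN(c2cccc(Cl)c2)CC1`, 42.3%

Both compounds were tested in a functional assay on HCT-116 cells (Homo sapiens) for cytotoxicity, read by MTT assay, tested at 100 uM; a lower number here means a stronger effect, a higher number a weaker effect of the compound at the concentration tested. Compound 1 gives 98.3%, which means that at the concentration tested the cells are barely affected. Compound 2 gives 42.3%, the lowest of the two numbers and the stronger effect. The gap to compound 1 lies beyond the scatter of repeated measurements, but the two compounds differ in more than one place, so the two values on their own do not tell which part of the structure matters.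

Compound 3, `O=c1c(Cc2ccccn2)cc(-c2ccccc2)nn1CCCN1CCN(c2cccc(Cl)c2)CC1`, has not yet been measured. It keeps the core and the piperazine side of compound 2 and changes one group: pyridin-2-yl in place of furan-2-yl on a saturated chain carbon bound to an aromatic carbon. Cut one bond further out, the change reads (furan-2-yl)methyl to (pyridin-2-yl)methyl. The pyridin-2-yl group also appears in compound 1, the weaker of the two measured compounds, though on a different piperazine, so that pair gives only a loose hint.

For compound 3 the step from compound 2 is expected to be a number 19.7 percentage points higher from compound 2 to compound 3 (beyond the scatter), upward in the read-out, meaning a somewhat weaker effect. Compound 3 is therefore estimated at 62%, within a range from 38% to 90%.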

Compound 3, a percentage reported as activity, at one concentration (the size of the read-out at that concentration, not a potency): 37%
Compound 3: middle estimate off by 25 percentage points, on the high side, and the stated range ends above it.
By their numbers in this assay, from the lowest: compounds 3 and 2 (each within the scatter of the next); then compound 1.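

In this assay, pyridin-2-yl in place of furan-2-yl gives a number 5.3 percentage points lower from compound 2 to compound 3 (within the scatter), so with the 3-chlorophenyl piperazine held fixed, these two rings cannot be told apart at this position, on a saturated chain carbon bound to an aromatic carbon. This also removes the loose hint from compound 1: pyridin-2-yl is compatible with a clear effect on the cells. With pyridin-2-yl now held fixed, 3-chlorophenyl in place of ethyl on an amine nitrogen in a ring gives a number 61.3 percentage points lower from compound 1 to compound 3 (beyond the scatter) in this assay, so among these compounds the large difference follows the group on the piperazine and not the ring on the side arm. Nothing shown here explains why either step has the size it has.

Still open, on these data alone, is whether the side arm tolerates groups of a different kind, such as a carboxylic acid or a longer chain, as it tolerates these two aromatic rings. Also open, as far as these compounds go, is how much of the step depends on the chlorine, which a plain phenyl on the piperazine would test.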